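Taking the last bromo off compound 3

The source may report more compounds than this note shows. Statements on the series, on what has been measured and on what is new or still open speak of the compounds shown alone.

In an ADME assay on BAEC cells (Bos taurus) for cytotoxicity, read by MTT assay, with a stated time of 2 days (a higher number here means a weaker inhibitor, a lower number a stronger inhibitor), compound 1 `COc1c(Br)cc(C=O)c(O)c1Br` gives 806000 nM as its reading. Compound 2 `COC1=C(Br)C(=O)[C@]2(C=C1Br)CO2` reads 161000 nM in the same measurement. Compound 3 `COC1=C(Br)C(=O)[C@]2(C=C1)CO2` reads 11000 nM and so holds the lowest number of the three, with compound 2 nearest and compound 1 furthest off.

Within the data shown here, compound 4 `COC1=CC(=O)[C@]2(C=C1)CO2` has no measurement yet. The change from compound 3 reads hydrogen in place of bromo on a double-bonded ring carbon and amounts to hydrogen in place of bromo on a double-bonded ring carbon, which leaves the core with no bromo at all.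

Among the measured compounds shown here, only one measured step bears on this. The same exchange at the other bromo-bearing ring carbon gave a 15-fold lower number from compound 2 to compound 3 (1.17 log units; beyond the scatter) as a large change, and a single precedent at a different ring carbon is a thin basis. A step in the same direction but of smaller size is therefore expected, and the estimated step is a 2.2-fold lower number from compound 3 to compound 4 (0.34 log units; beyond the scatter) with wide margins on it. For compound 4 the estimated value in this assay is 5000 nM with 1200 nM to 20000 nM as the expected range.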

Compound 4, half-maximal inhibitory concentration: 33000 nM
For compound 4 the middle estimate is 6.6-fold (0.82 log units) below the measured one, outside the stated range (above it).
By their numbers in this assay, from the lowest: compound 3; then compound 4; then compound 2; then compound 1.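

In this assay the exchange of bromo for hydrogen has a direction that depends on where it happens: on the double-bonded ring carbon next to the ring atom that bears a methoxy group it gives a 3.0-fold higher number from compound 3 to compound 4 (0.48 log units; beyond the scatter) and not a further fall, while at the other bromo-bearing ring carbon it gave a 15-fold lower number from compound 2 to compound 3 (1.17 log units; beyond the scatter) as the larger of the two steps. Both steps lie beyond the scatter, so the two bromo-bearing carbons have to be read as separate positions on this core, and a result at one does not carry over to the other. No measurement at hand accounts for the opposite directions of these two steps.

Still open is whether the step at this carbon would keep its direction and size with a bromo on the other ring carbon, which the compounds shown cannot answer. Also open, on these data alone, is where a chloro or a methyl group on this carbon would fall relative to compound 3 and compound 4, and what a hydroxyl or an amine in place of the methoxy group would do.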